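Compound 4: Estimating One Change on the Ring

The source may report more compounds than this note shows. Statements on the series, on what has been measured and on what is new or still open speak of the compounds shown alone.

Of the compounds shown here, three sharing one core have been tested so far. In an ADME assay on HeLa cells (Homo sapiens) for cytotoxicity (a lower number here means a stronger inhibitor, a higher number a weaker inhibitor), compound 2 (`Cc1ncc([N+](=O)[O-])n1CCSC(=S)N1CCC(C)CC1`) gives 190 ug/mL and holds the lower of the two exact numbers. Compound 3 (`Cc1ncc([N+](=O)[O-])n1CCSC(=S)N1CCC(O)CC1`) gives 930 ug/mL and so sits higher. Compound 1 (`Cc1ncc([N+](=O)[O-])n1CCSC(=S)N1CCC2(CC1)OCCO2`) gives > 1000 ug/mL as its result, which is a limit of the assay and not a number.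

Compound 4 (`Cc1ncc([N+](=O)[O-])n1CCSC(=S)N1CCC(OC(=O)CCl)CC1`) has not yet been measured. It differs from compound 2 by one change (((chloromethyl)carbonyl)oxy in place of methyl on a saturated ring carbon) with ((chloromethyl)carbonyl)oxy in place of methyl on a saturated ring carbon. Going by the values given here, only one measured step bears on this change, namely a 4.9-fold higher number from compound 2 to compound 3 (0.69 log units; beyond the scatter) for hydroxy in place of methyl, a modest step beyond the scatter. Compound 3 carries a hydroxy that compound 4 lacks, so that step is only a loose guide. A rise smaller than that one is therefore expected in this assay and the estimated change is a 2.1-fold higher number from compound 2 to compound 4 (0.32 log units; beyond the scatter) with real uncertainty in both directions. The expected value for compound 4 is 400 ug/mL with an estimated range from 90 ug/mL to 1000 ug/mL around it.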

Compound 4, half-maximal inhibitory concentration: 930 ug/mL
Beside the measured number, compound 4's estimate is 2.3-fold (0.37 log units) below it; the range from low to high includes it.
By their numbers in this assay, from the lowest: compound 2; then compounds 3 and 4 (each within the scatter of the next). At a limit, above all of these: compound 1.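

In this assay, replacing methyl with the much larger ((chloromethyl)carbonyl)oxy on this saturated ring carbon gives a 4.9-fold higher number from compound 2 to compound 4 (0.69 log units; beyond the scatter), a rise of the same printed size as a 4.9-fold higher number from compound 2 to compound 3 (0.69 log units; beyond the scatter). Placing (chloromethyl)carbonyl on the oxygen of compound 3 gives no change at the digits printed from compound 3 to compound 4 (within the scatter), so in this assay, keeping or replacing the hydrogen on that oxygen makes no visible difference. Across these compounds, the higher number therefore follows the presence of an oxygen on this ring carbon and not the size of the group, although only compound 3 and compound 4 support that reading and they do not prove the oxygen is what matters.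

Going by these compounds alone, no compound with an amine on the same ring carbon, or with a longer carbon chain with no oxygen in it, has been measured. Such a compound would show whether the rise is also seen without an oxygen on this ring carbon. Any further rise at this position may also run into the top of the readable range: the limit of > 1000 ug/mL in this assay, at which 1 of the 4 values shown sits.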